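Working notes: from compound 3 to compound 4

The source may hold more compounds than are shown below. What is called first, only, known or untested is meant among the compounds shown, and "the series" means these compounds.

In a functional assay on G-361 cells (Homo sapiens) for antiproliferative activity, with a stated time of 72 h (a lower number here means a stronger inhibitor, a higher number a weaker inhibitor), compound 1 `COc1cccc(CNc2ncnc3c2ncn3[C@@H]2O[C@H](CO)[C@@H](O)[C@H]2O)c1` has no usable result, being recorded as "not determined" (no result reported). Compound 2 `OC[C@H]1O[C@@H](n2cnc3c(NCc4c(F)ccc(F)c4F)ncnc32)[C@H](O)[C@@H]1O` reads > 166000 nM, which is a limit of the assay and not a number. Compound 3 `OC[C@H]1O[C@@H](n2cnc3c(NCc4ccc(F)c(Cl)c4)ncnc32)[C@H](O)[C@@H]1O` reads > 166000 nM, which is likewise only a limit. The series therefore has a single anchor in this assay, namely (the limit of > 166000 nM in this assay, at which 2 of the 3 values shown sit).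

Compound 4 `Cc1cccc(CNc2ncnc3c2ncn3[C@@H]2O[C@H](CO)[C@@H](O)[C@H]2O)c1O` carries 2-hydroxy-3-methylphenyl in place of 3-chloro-4-fluorophenyl on a saturated chain carbon bound to a nitrogen on an aromatic ring. Within the data shown here, the only measured step that bears on this change is a step that the two limits leave unreadable from compound 2 to compound 3, and it offers no size to carry forward. Among the measured compounds shown here, no measured compound carries 2-hydroxy-3-methylphenyl, so the data fix neither the size nor the direction of the coming step. A reading at the same limit remains a likely outcome. A measurable value could only appear on the stronger side of that limit, so the expectation leans that way, with low confidence. The expected step is an at least 4.1-fold lower number from compound 3 to compound 4 (0.61 log units; beyond the scatter), an estimate with a wide margin. For compound 4 the estimated value is 40000 nM, with an expected range from 4000 nM to 166000 nM.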

Compound 4, half-maximal inhibitory concentration: > 166000 nM
Compound 4 gave a limit, no number (the forecaster's own chance of this, stated with the estimate: 45%); at least 4.1-fold (0.61 log units) between middle value and limit.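

In this assay, among these compounds, no step among compound 2, compound 3 and compound 4 can be read, since each result is a limit and not a number: the limit of > 166000 nM in this assay, at which 3 of the 4 values shown sit. The compounds shown leave open whether any of these benzyl groups on the shared core gives a measurable value, and how large a step between them would be.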